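Removing the benzyl group from a selenium-bearing quinazoline-type core

A few compounds are considered here, and "the series" means these few. Any claim that something is new, unique, unknown or untested is made for them only; others in the source may bear on it.

Compound 1 `C[Se]c1nc(N)c2ccccc2n1` gives 65100 nM in a functional assay on CCRF-CEM cells (Homo sapiens) for cytotoxicity, read by MTT assay, with a stated time of 72 h; a lower number here means a stronger inhibitor of growth, a higher number a weaker inhibitor of growth.
Compound 2 `CCCCC[Se]c1nc([Se]CCCCC)c2ccccc2n1` gives 65700 nM in this assay.
Compound 3 `CCCCC[Se]c1nc(NCc2ccccc2)c2ccccc2n1` gives 34500 nM in this assay.

All three measured compounds share one core and differ only in the two groups attached to it. Compound 3 sits at the low end of the three numbers, yet compound 1 and compound 2 both lie within the scatter of it, so no ordering among them can be claimed. Going by the values given here, the one single-point step measured, a 1.9-fold lower number from compound 2 to compound 3 (0.28 log units; within the scatter), is itself within the scatter.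

Compound 4 `CCCCC[Se]c1nc(N)c2ccccc2n1` is not yet measured. It differs from compound 3 by hydrogen in place of benzyl on a nitrogen on an aromatic ring. Among the compounds with values here, no measured pair reproduces this exact change. The closest guide is compound 1, which carries the same amino group on a shorter selenium chain and gives 65100 nM, a number within the scatter of compound 3. On that basis a step of a 1.4-fold higher number from compound 3 to compound 4 (0.16 log units; within the scatter) is expected, which is not beyond the scatter. Compound 4 is therefore estimated at 50000 nM, with a plausible range from 20000 nM to 120000 nM.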

Compound 4, concentration for 50% growth inhibition: 34800 nM
Estimate against measurement, compound 4: 1.4-fold (0.16 log units) above, within the range that was stated.
By their numbers in this assay, from the lowest: compounds 3, 4, 1 and 2 (each within the scatter of the next).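

The direct test of this position in this assay is a 1.0-fold higher number from compound 3 to compound 4 (0.00 log units; within the scatter), so the change from benzylamino to amino on the aromatic ring leaves no difference that can be read. The other two new steps, a 1.9-fold lower number from compound 2 to compound 4 (0.28 log units; within the scatter) and a 1.9-fold lower number from compound 1 to compound 4 (0.27 log units; within the scatter), are also within the scatter, so neither change gives a readable difference: one nitrogen atom in place of the larger selenium-bearing group on an aromatic carbon, or butyl in place of hydrogen on the chain carbon bound to a selenium atom. Nothing available here bears on why these numbers stay so close.

From the compounds shown here alone, it remains open whether a carboxylic acid on the benzyl ring, or a morpholine in place of the amino group, would give a step beyond the scatter. The same question stands for a longer chain, such as decyl, on the selenium atom.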